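The source may hold more compounds than are shown below. What is called first, only, known or untested is meant among the compounds shown, and "the series" means these compounds.

Measured so far in an ADME assay on MT2 cells (Homo sapiens) for cytotoxicity, read by MTT assay; a lower number here means that less compound is tolerated, a higher number that more compound is tolerated:
- compound 1 `N#Cc1cc2c(Oc3ccccc3OCCn3ccc(=O)[nH]c3=O)cc(F)cn2c1`: 40000 nM
- compound 2 `Cc1ccc2c(Oc3ccccc3OCCn3ccc(=O)[nH]c3=O)cccc2c1`: 40000 nM
- compound 3 `N#Cc1cc2c(Oc3ccc(F)cc3OCCn3ccc(=O)[nH]c3=O)cccc2o1`: > 100000 nM, a limit of the assay rather than a number

Compound 2 stands level with compound 1 at the digits shown, the two values sitting within the scatter of each other, so no order between them can be read. Of the three values shown, one sits at the limit of > 100000 nM in this assay, at which 1 of the 3 values shown sits, and that value belongs to compound 3 alone. All three compounds are thus tolerated up to high concentration in this assay, and nothing in the set separates the aromatic cores from each other.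

Compound 4 `O=c1ccn(CCOc2ccccc2Oc2cccc3cc(Cl)ccc23)c(=O)[nH]1` differs from compound 2 by chloro in place of methyl on an aromatic carbon. Among the measured compounds shown here, no measured pair carries a change of this kind, so the size of the step has to be judged from the flat picture of the three values alone. The expected step of no change at the digits printed from compound 2 to compound 4 (within the scatter) is none beyond the scatter. For compound 4 the estimated value in this assay is 40000 nM, with a range from 15000 nM to 100000 nM.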

Compound 4, half-maximal cytotoxic concentration: > 100000 nM
Compound 4: a limit, no number (the forecaster's own chance of this, stated with the estimate: 30%); middle value at least 2.5-fold (0.39 log units) away from the limit.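

In this assay compound 4 gives > 100000 nM, a limit of the assay and not a number. Chloro in place of methyl on this aromatic carbon of the fused system gives an at least 2.5-fold higher number from compound 2 to compound 4 (0.39 log units; beyond the scatter), the only step in the series between compounds that differ in one place, so this position can shift the tolerated concentration in this assay, which the earlier compounds could not show. Only a lower bound on the size of this step can be read, as the values of the series now reach the top of the range in two cases: the limit of > 100000 nM in this assay, at which 2 of the 4 values shown sit.

Going by these compounds, how far compound 4 lies beyond that limit stays open, and so does whether the same exchange would give a step on the core of compound 1. On these data alone, whether an amine, a carboxylic acid or a longer alkyl chain on this aromatic carbon would move the value the same way also stays open.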